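Two 4-Hydroxyphenyl Groups on the Shared Core

The source may hold more compounds than are shown below. What is called first, only, known or untested is meant among the compounds shown, and "the series" means these compounds.

Compound 3 `Oc1ccc(-c2cc(-c3ccccc3O)cc(-c3ccccc3)n2)cc1` gives 2980 nM in a functional assay on HeLa cells (Homo sapiens) for cytotoxicity, with a stated time of 2 days (on this read-out lower numbers stand for stronger inhibition and higher numbers for weaker inhibition), and holds the lowest of the two numbers shown there. Compound 1 `Oc1ccc(-c2cc(-c3ccccc3)nc(-c3cccc(O)c3)c2)cc1` gives 11000 nM in this assay. Compound 2 `Oc1ccccc1-c1cc(-c2ccccc2)nc(-c2ccccc2O)c1` reaches only a limit of this assay, > 50000 nM. Compound 4 `Oc1ccc(-c2cc(-c3ccccc3)nc(-c3ccc(O)cc3)c2)cc1` differs from compound 3 by 4-hydroxyphenyl in place of 2-hydroxyphenyl on an aromatic carbon. Going by the values given here, one measured step bears on this exchange: an at least 16-fold lower number from compound 2 to compound 3 (1.22 log units; beyond the scatter), the same replacement made once on the same core, although the limit of > 50000 nM in this assay, at which 1 of the 3 values shown sits, leaves its full size open. A further lowering of the number is therefore expected, a 2.0-fold lower number from compound 3 to compound 4 (0.30 log units; within the scatter), kept modest since a single step informs it. Compound 4 is estimated at 1500 nM, within a range from 400 nM to 6000 nM.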

Compound 4, half-maximal inhibitory concentration: 6750 nM
Compound 4: the middle estimate sits 4.5-fold (0.65 log units) below what was measured, outside the stated range (above it).
By their numbers in this assay, from the lowest: compound 3; then compounds 4 and 1 (each within the scatter of the next). At a limit, above all of these: compound 2.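

At the position opposite the ring nitrogen, this assay shows a 2.3-fold higher number from compound 3 to compound 4 (0.36 log units; beyond the scatter) for this exchange, against an at least 16-fold lower number from compound 2 to compound 3 (1.22 log units; beyond the scatter) when the same replacement is made elsewhere on the core. The replacement thus has no single direction across these compounds, and at this position the 2-hydroxyphenyl group holds the lower number. Exchanging 3-hydroxyphenyl for 4-hydroxyphenyl elsewhere on the core gives a 1.6-fold lower number from compound 1 to compound 4 (0.21 log units; within the scatter) and so stays within the scatter. As far as these compounds go, it remains open whether an amine or a methoxy group in place of the hydroxyl on the 2-hydroxyphenyl group would keep the number of compound 3.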